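Removing the methyl group from compound 3

The source may hold more compounds than are shown below. What is called first, only, known or untested is meant among the compounds shown, and "the series" means these compounds.

In a functional assay on Hep cells (Homo sapiens) for cytotoxicity, read by sulforhodamine B assay, with a stated time of 48 h (a lower number here means a stronger inhibitor, a higher number a weaker inhibitor), compound 1 `C=CCOc1cc(Br)ccc1C(=O)c1cccnc1` reports only a limit, > 100000 nM. Compound 2 `C=CCOc1ccc(Br)cc1C(=O)c1cccnc1` gives 78000 nM, and compound 3 `C=CCOc1ccc(C)cc1C(=O)c1cccnc1` gives 72000 nM. These two numbers lie within the scatter of each other, so compound 3 stands level with compound 2. Compound 4 `C=CCOc1ccccc1C(=O)c1cccnc1` differs from compound 3 by hydrogen in place of methyl on an aromatic carbon, para to an allyloxy group: hydrogen in place of methyl on an aromatic carbon. Going by the values given here, one measured step bears on this change: a 1.1-fold lower number from compound 2 to compound 3 (0.03 log units; within the scatter), with methyl replacing bromo on that carbon. A change beyond the scatter is therefore not expected in this assay, and the estimated step is a 1.0-fold higher number from compound 3 to compound 4 (0.02 log units; within the scatter). For compound 4 the expected value is 75000 nM, with an estimated range of 42000 nM to 100000 nM.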

Compound 4, half-maximal inhibitory concentration: > 100000 nM
Compound 4 ended at the assay's limit; the forecaster's own chance of this, stated with the estimate: 15%; at least 1.3-fold (0.12 log units) between middle value and limit.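

In this assay, compound 4 gives only a limit, > 100000 nM. Going by these compounds alone, this limit sets floors rather than sizes, an at least 1.3-fold higher number from compound 3 to compound 4 (0.14 log units; that floor lies within the scatter) and an at least 1.2-fold higher number from compound 2 to compound 4 (0.10 log units; that floor lies within the scatter), so hydrogen on this carbon, para to an allyloxy group, is the first change here whose step has no upper bound, though neither floor clears the scatter. The step linking compound 1 with compound 4 cannot be read, and the limit now recurs in this series: the limit of > 100000 nM in this assay, at which 2 of the 4 values shown sit.

The compounds shown leave open how far past the limit compound 4 lies, and whether an amine or a carboxylic acid on this carbon would move the number beyond the scatter from compound 3.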